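Shrinking a Saturated Ring on a Weak Cell-Growth Inhibitor

A few compounds are considered here, and "the series" means these few. Any claim that something is new, unique, unknown or untested is made for them only; others in the source may bear on it.

Compound 1 `c1cc(N2CCCCC2)nc(Nc2ccc(Oc3ncnc4sccc34)cc2)n1` and compound 2 `CN(c1ccc(Oc2ncnc3ccsc23)cc1)c1nccc(N2CCc3ccccc3C2)n1` share a common core and differ in several places. In a functional assay on A549 cells (Homo sapiens) for inhibition, read by MTT assay, with a stated time of 72 h (on this read-out lower numbers stand for stronger inhibition and higher numbers for weaker inhibition), compound 1 gives 4020 nM, while compound 2 gives 16200 nM, the higher of the two numbers and therefore the weaker inhibitor; the gap between them lies beyond the usual scatter of repeated measurements. Compound 3 `CN(c1ccc(Oc2ncnc3ccsc23)cc1)c1nccc(N2CCc3ccccc32)n1` keeps the frame of compound 2 and differs from it in one place: 2,3-dihydro-1H-indol-1-yl in place of 1,2,3,4-tetrahydroisoquinolin-2-yl on an aromatic carbon. Among the measured compounds shown here, no measured pair in this set carries exactly this change, so the only guide is the change itself, which swaps one group for a closely related one. The step of a 1.4-fold lower number from compound 2 to compound 3 (0.13 log units; within the scatter) is therefore expected to be small, within the scatter, with no firm direction. On that basis compound 3 is estimated at 12000 nM in this assay, with a range from 4000 nM to 36000 nM.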

Compound 3, half-maximal inhibitory concentration: 20500 nM
Estimate against measurement, compound 3: 1.7-fold (0.23 log units) below; the measured number falls inside the stated range.
By their numbers in this assay, from the lowest: compound 1; then compounds 2 and 3 (each within the scatter of the next).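

In this assay the swap of 1,2,3,4-tetrahydroisoquinolin-2-yl for 2,3-dihydro-1H-indol-1-yl, on the aromatic carbon next to the ring nitrogen, gives a 1.3-fold higher number from compound 2 to compound 3 (0.10 log units; within the scatter) and so makes no readable difference. Among the compounds shown here, this is the first comparison here that isolates one place, and it shows that going from a six-membered to a five-membered non-aromatic ring, with the carbon-only aromatic ring kept, leaves this read-out effectively unmoved. Nothing measured here explains why this position tolerates the swap.

Still open, on these data alone, is whether a group of a different kind at this position, such as a morpholine ring or a simple dimethylamino group, would shift the number beyond the scatter. Compound 1 differs from both compounds in several places, so its lower number cannot be traced to any one of them.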